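Cyclohexyl for trifluoromethylpyridyl on the benzylamine arm

A few compounds are considered here, and "the series" means these few. Any claim that something is new, unique, unknown or untested is made for them only; others in the source may bear on it.

Three compounds share one core and vary only in the group on the aromatic carbon of the benzylamine ring. Compound 1 `COc1ccc(CNc2nc(-c3ccccc3C(F)(F)F)nc3ccccc23)cc1` carries methoxy there and gives 6200 nM in an assay on a protein complex for inhibition of ubiquitin carboxyl-terminal hydrolase 1/WD repeat-containing protein 48 (Homo sapiens), read by fluorescence; on this read-out lower numbers stand for stronger inhibition and higher numbers for weaker inhibition. Compound 2 `FC(F)(F)c1ccccc1-c1nc(NCc2ccc(-c3ccncc3)cc2)c2ccccc2n1` carries pyridin-4-yl and gives 1900 nM; the step is a 3.3-fold lower number from compound 1 to compound 2 (0.51 log units; beyond the scatter). Compound 3 `FC(F)(F)c1cc(-c2ccc(CNc3nc(-c4ccccc4C(F)(F)F)nc4ccccc34)cc2)ccn1` carries 2-(trifluoromethyl)pyridin-4-yl and gives 4900 nM; against compound 1 this is a 1.3-fold lower number from compound 1 to compound 3 (0.10 log units; within the scatter), and against compound 2 it is a 2.6-fold higher number from compound 2 to compound 3 (0.41 log units; beyond the scatter). Compound 3 therefore sits second highest of the three numbers, close to compound 1 and clearly above compound 2.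

Compound 4 `FC(F)(F)c1ccccc1-c1nc(NCc2ccc(C3CCCCC3)cc2)c2ccccc2n1` is the next change at the same place: cyclohexyl in place of 2-(trifluoromethyl)pyridin-4-yl on an aromatic carbon. Among the compounds with values here, no measured step swaps an aromatic ring for a saturated one here, so the bearing steps are only indirect. The two ring-for-methoxy steps, compound 1 to compound 2 and compound 1 to compound 3, and the trifluoromethyl step from compound 2 to compound 3 all stayed modest, spanning roughly the width between compound 2 and compound 1. A step of similar modest size in this assay, most likely downward toward compound 2, is expected for compound 4, that is a 1.4-fold lower number from compound 3 to compound 4 (0.15 log units; within the scatter). Compound 4 is estimated at 3500 nM, with a range from 1200 nM to 10000 nM.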

Compound 4, half-maximal inhibitory concentration: 9800 nM
Estimate against measurement, compound 4: 2.8-fold (0.45 log units) below, within the range that was stated.
By their numbers in this assay, from the lowest: compound 2; then compounds 3, 1 and 4 (each within the scatter of the next).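

In this assay, within the data shown here, the saturated cyclohexyl ring gives the largest step yet seen at this position, a 5.2-fold higher number from compound 2 to compound 4 (0.71 log units; beyond the scatter), and this confirms compound 2, with its pyridin-4-yl, as the only compound here that separates from all the others beyond the scatter. The other two steps, a 2.0-fold higher number from compound 3 to compound 4 (0.30 log units; within the scatter) and a 1.6-fold higher number from compound 1 to compound 4 (0.20 log units; within the scatter), leave cyclohexyl indistinguishable from both 2-(trifluoromethyl)pyridin-4-yl and methoxy, so a ring nitrogen does not sort the series by itself: compound 2 and compound 3 both carry one, yet compound 3 cannot be told apart from compound 4, which has no hetero atom in that ring. Nothing measured on these compounds accounts for the advantage of compound 2 over compound 4.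

Still open, on these data alone, is whether that advantage depends on the ring nitrogen or on aromaticity, which a plain phenyl ring or a morpholine at the same place would help to separate. The trifluoromethyl step also stands alone on the pyridine ring, so it remains unclear whether a smaller group such as methyl or fluorine would keep the number of compound 2 or lose it as compound 3 does.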